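Thiophen-3-yl for furan-2-yl at an assay limit

This account rests on a few compounds, and the source may have more. Where it says the series, first, only, none or still open, it means among the compounds named here.

In an ADME assay on Raji cells (Homo sapiens) for cytotoxicity, read by CellTiter-Glo and resazurin assay, with a stated time of 72 h (a lower number here means that less compound is needed, a higher number that more compound is needed for the effect), compound 1 (`CC(C)N(Cc1cccc(OCCCCCC(=O)O)c1)C(=O)c1ccc(-c2cccc(-c3ccccc3)c2)cc1`) gives > 26000 nM as a limit and not a number. Compound 2 (`CC(=O)c1cccc(-c2ccc(C(=O)N(Cc3cccc(OCCCCCC(=O)O)c3)C(C)C)cc2)c1`) gives > 26000 nM as a limit too. Compound 3 (`CC(C)N(Cc1cccc(OCCCCCC(=O)O)c1)C(=O)c1ccc(-c2ccco2)cc1`) gives > 26000 nM as a limit as well. Compound 3 thus stands with the other two at the limit of > 26000 nM in this assay, at which 3 of the 3 values shown sit, here. Compound 4 (`CC(C)N(Cc1cccc(OCCCCCC(=O)O)c1)C(=O)c1ccc(-c2ccsc2)cc1`) carries thiophen-3-yl in place of furan-2-yl on an aromatic carbon. The measured steps that bear on this change are a step that the two limits leave unreadable from compound 1 to compound 3 and a step that the two limits leave unreadable from compound 2 to compound 3 and neither has a readable size. What is expected is a number no higher from compound 3 to compound 4 (the limit leaves the size open) and no step beyond the scatter in either direction. For compound 4 the estimated value is 26000 nM with an expected range from 15000 nM to 50000 nM and most likely another limit.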

Compound 4, half-maximal effective concentration: > 26000 nM
Compound 4 was reported as a limit; the forecaster's own chance of this, stated with the estimate: 85%; the middle value sits exactly at the limit.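

Compound 4, like compounds 1, 2 and 3, gives a limit and not a number, so no step to compound 4 can be read: the limit of > 26000 nM in this assay, at which 4 of the 4 values shown sit.

Going by these compounds, whether any of these groups on the shared core changes the result in this assay stays open.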